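A few compounds are considered here, and "the series" means these few. Any claim that something is new, unique, unknown or untested is made for them only; others in the source may bear on it.

In a functional assay on HCT-116 cells (Homo sapiens) for cytotoxicity, read by sulforhodamine B assay, with a stated time of 48 h (on this read-out lower numbers stand for stronger inhibition and higher numbers for weaker inhibition), compound 1 (`CCCCNC(=O)N1Cc2c(NC(=O)c3ccc(F)cc3)nn(C(=O)c3ccccc3)c2C1`) gives 30800 nM and compound 2 (`O=C(Nc1nn(C(=O)C2CC2)c2c1CN(C(=O)c1ccccc1)C2)c1ccc(F)cc1`) gives 2280 nM as the lower of the two numbers, a gap beyond the usual scatter. These two compounds differ in more than one place, so their gap cannot be assigned to any single group. Compound 3 (`O=C(Nc1nn(C(=O)c2ccccc2)c2c1CN(C(=O)c1ccccc1)C2)c1ccc(F)cc1`) has not yet been measured. It departs from compound 2 in one place, with phenyl in place of cyclopropyl on a carbonyl carbon, which reads as cyclopropylcarbonyl to benzoyl. Going by the values given here, no measured pair shows this change alone. Compound 1 also carries benzoyl there and stands at 30800 nM but differs elsewhere too, so it is only a weak pointer towards a higher number. The expected change is small (a 1.3-fold higher number from compound 2 to compound 3 (0.12 log units; within the scatter)), a slight rise estimated to stay within the scatter. For compound 3 the estimated value is 3000 nM (expected range 800 nM to 12000 nM).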

Compound 3, half-maximal inhibitory concentration: 2780 nM
Compound 3: middle estimate off by 1.1-fold (0.03 log units), on the high side; measured number inside the range.
By their numbers in this assay, from the lowest: compounds 2 and 3 (each within the scatter of the next); then compound 1.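

In this assay, the carbonyl carbon on the aromatic nitrogen accepts either group without a readable difference: cyclopropylcarbonyl to benzoyl gives a 1.2-fold higher number from compound 2 to compound 3 (0.09 log units; within the scatter). The other carbonyl carbon now has a single-change reading, which the earlier pair of compounds could not give: phenyl in place of butylamino gives an 11-fold lower number from compound 1 to compound 3 (1.04 log units; beyond the scatter), so this is the position in the shown compounds where a change registers beyond the scatter. Nothing on hand gives a cause for either step.

Still open, as far as these compounds go, is whether the flat reading on the aromatic nitrogen side holds for a longer alkyl chain or a dimethylamino group on that carbonyl carbon. Also open, from the compounds shown here alone, is how a piperidine or a methoxy group would read on the other carbonyl carbon, where only phenyl and butylamino can be compared so far.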